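From 4-methylphenyl to cyclopropyl: expecting compound 4

A few compounds are considered here, and "the series" means these few. Any claim that something is new, unique, unknown or untested is made for them only; others in the source may bear on it.

Measured so far in a functional assay on A-375 cells (Homo sapiens) for antiproliferative activity, read by MTT assay, with a stated time of 72 h (a higher number here means a weaker inhibitor, a lower number a stronger inhibitor), by compound:
Compound 1 `COc1ncc(-c2ccc3c(c2)N(c2ccc(C)cc2)C(=O)CO3)cc1NS(=O)(=O)c1ccc(F)cc1` gives 12900 nM
Compound 2 `CC(C)N1C(=O)COc2ccc(-c3cnc(Cl)c(NS(=O)(=O)c4ccc(F)cc4)c3)cc21` gives 25500 nM
Compound 3 `O=C1COc2ccc(-c3cccc(NS(=O)(=O)c4ccc(F)cc4)c3)cc2N1c1ccc(Cl)cc1` gives 32500 nM

Repeated measurements of this kind scatter, so small gaps between numbers carry no meaning. Compound 1 and compound 2 cannot be told apart on these numbers. Only compound 3 is separated from compound 1 by more than the scatter, and it has the higher number, which means a weaker inhibitor.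

The next compound is compound 4 `COc1ncc(-c2ccc3c(c2)N(C2CC2)C(=O)CO3)cc1NS(=O)(=O)c1ccc(F)cc1`, which keeps the core of compound 1 but has cyclopropyl in place of 4-methylphenyl on an amide-type nitrogen in a ring. For the measured compounds named here, no two measured compounds differ in only one place, so the data give no direct measure of what such a swap does in this assay and the forecast is loose. Going by the values given here, the only guide is the narrow band of the measured set, from compound 1 (12900 nM) to compound 3 (32500 nM). A small move towards a higher number is expected, most likely not beyond the scatter. The expected step is a 1.6-fold higher number from compound 1 to compound 4 (0.19 log units; within the scatter) and this is only an estimate. For compound 4 the estimated value is 20000 nM (expected range 7000 nM to 50000 nM).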

Compound 4, half-maximal inhibitory concentration: 23900 nM
Beside the measured number, compound 4's estimate is 1.2-fold (0.08 log units) below it; the measured number falls inside the stated range.
By their numbers in this assay, from the lowest: compounds 1, 4, 2 and 3 (each within the scatter of the next, the first and the last beyond it).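

In this assay, for the compounds shown here, cyclopropyl in place of 4-methylphenyl on the amide-type nitrogen in a ring is the first single change that can be read directly, and it gives a 1.9-fold higher number from compound 1 to compound 4 (0.27 log units; within the scatter). With the rest of the molecule held constant, a six-membered aromatic ring of 7 heavy atoms can therefore be exchanged at this position for a three-membered non-aromatic ring of 3 heavy atoms, and the two compounds still cannot be told apart on these numbers. Nothing available explains why this exchange leaves the two numbers within the scatter of each other.

This single pair cannot show whether the position would respond to a group of another kind, such as a longer chain like n-butyl, a chain ending in an amine, or a phenyl ring carrying a carboxylic acid. Compound 2 and compound 3 each differ from compound 1 in more than one place, so they cannot separate the effect of the group on this nitrogen from that of the other differences.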